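Propyl for isopropyl on the shared core

The compounds below may be only part of what the source reports. "The series", "measured", "known", "first", "only" and "open" are said of these compounds alone.

The shared core of compound 1 `CC(C)n1nccc1-c1ccccc1NCC1=NCCN1` carries an isopropyl on an aromatic nitrogen of a five-membered aromatic ring with 2 nitrogen. In an in vitro functional assay on cells (Fibroblast) for agonist activity at Alpha-1D adrenergic receptor (Homo sapiens) (a higher number here means that more compound is needed for the effect, a lower number that less compound is needed), compound 1 gives < 100000 nM, which is a limit of the assay rather than a number. Compound 2 `CCn1ncnc1-c1ccccc1NCC1=NCCN1` has a different five-membered ring on the same scaffold, and in this assay compound 2 gives 126 nM. Among the compounds with values here, of these two values, one sits at the limit, as the evidence notes (the limit of < 100000 nM in this assay, at which 1 of the 2 values shown sits), so no measured step between them can be stated as a number.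

Compound 3 `CCCn1nccc1-c1ccccc1NCC1=NCCN1` is the untested partner of compound 1; the two have the same atoms, joined differently. propyl in place of isopropyl on an aromatic nitrogen

Because compound 1 is known only from its limit < 100000 nM, the size of the step to compound 3 cannot be anchored. He would expect the step that the limit leaves unreadable from compound 1 to compound 3 to be modest, with no clear direction beyond the scatter. His estimate for compound 3 in this assay is 800 nM, expected to lie between 80 nM and 10000 nM.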

Compound 3, half-maximal effective concentration: < 100000 nM
Compound 3: only a limit was reported (the forecaster's own chance of this, stated with the estimate: 20%); the middle value is on the limit's open side.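

In this assay compound 3 gives < 100000 nM, which is a limit of the assay and not a number. Within the data shown here, compound 1 also stands at a limit, so no step between compound 1 and compound 3 can be read: the limit of < 100000 nM in this assay, at which 2 of the 3 values shown sit. The compounds shown leave open whether propyl and isopropyl on the aromatic nitrogen differ at all in this assay.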